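Ring-nitrogen substituents in a weakly antiproliferative series

The compounds below may be only part of what the source reports. "The series", "measured", "known", "first", "only" and "open" are said of these compounds alone.

Compound 1 `NC(=O)c1c(NC(=O)c2ccccc2Cl)sc2c1CCNC2` carries a free amine in its saturated ring; in a functional assay on HeLa cells (Homo sapiens) for antiproliferative activity, with a stated time of 24 h (on this read-out higher numbers stand for weaker inhibition and lower numbers for stronger inhibition), compound 1 gives 45000 nM. Compound 2 `NC(=O)c1c(NC(=O)c2ccccc2Cl)sc2c1CCN(Cc1ccccc1)C2` puts benzyl on that nitrogen and gives 38400 nM in this assay, so that a 1.2-fold lower number from compound 1 to compound 2 (0.07 log units; within the scatter). Compound 3 `NC(=O)c1c(NC(=O)c2ccccc2Cl)sc2c1CCN(Cc1ccccc1F)C2` carries 2-fluorobenzyl on the same nitrogen. For compound 3 this assay reports only a limit, > 50000 nM, which is the limit of > 50000 nM in this assay, at which 1 of the 3 values shown sits. Compound 3 thus stands at the edge of the measured range without a number of its own, and both an at least 1.1-fold higher number from compound 1 to compound 3 (0.04 log units; that floor lies within the scatter) and an at least 1.3-fold higher number from compound 2 to compound 3 (0.11 log units; that floor lies within the scatter) are floors rather than steps of known size.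

Compound 4 `NC(=O)c1c(NC(=O)c2ccccc2Cl)sc2c1CCN(C(=S)Nc1ccccc1)C2` changes the substituent on the ring nitrogen: a group of 9 heavy atoms (7 carbon, 1 nitrogen, 1 sulfur; one six-membered aromatic ring of carbon only) in place of a group of 8 heavy atoms (7 carbon, 1 fluorine; one six-membered aromatic ring of carbon only), on an amine nitrogen in a ring. For the measured compounds named here, the steps that bear on this position all concern groups on the ring amine nitrogen, and none of them moved the read-out beyond the scatter. Going by the values given here, no compound with such a group at this nitrogen has yet been measured, so the prior steps give no direction. For compound 4 the expected step is an at least 1.1-fold lower number from compound 3 to compound 4 (0.04 log units; that floor lies within the scatter), no further than the scatter allows. Compound 4 is estimated in this assay at 45000 nM, between 15000 nM and 120000 nM, with a real chance that only a limit is reported again.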

Compound 4, half-maximal inhibitory concentration: 46700 nM
Compound 4: the middle estimate sits 1.0-fold (0.02 log units) below what was measured; low and high end bracket the measured number.
By their numbers in this assay, from the lowest: compounds 2, 1 and 4 (each within the scatter of the next). At a limit, above all of these: compound 3.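

In this assay, the group in compound 4 brings nitrogen, sulfur, a hydrogen-bond donor and a hydrogen-bond acceptor to the amine nitrogen in a ring, yet the read-out stays within the scatter of the earlier values: a 1.0-fold higher number from compound 1 to compound 4 (0.02 log units; within the scatter), and a 1.2-fold higher number from compound 2 to compound 4 (0.08 log units; within the scatter). The earlier numbers covered only hydrogen and benzyl at this nitrogen, so the flat result now extends to a group of a different atom make-up, and compounds 1, 2 and 4 cannot be ordered among themselves. The comparison with the 2-fluorobenzyl compound gives only a floor, an at least 1.0-fold lower number from compound 3 to compound 4 (0.02 log units; that floor lies within the scatter), and its true size cannot be read, since the value of compound 3 is a limit and not a number: the limit of > 50000 nM in this assay, at which 1 of the 4 values shown sits.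

As far as these compounds go, whether any substituent on this nitrogen can move the read-out beyond the scatter remains open, and these compounds offer no direction for it. From the compounds shown here alone, what a carboxylic acid, a longer alkyl chain or an acetyl group at this nitrogen would give is unknown, as is the effect of any change elsewhere on the shared core.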